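The source may report more compounds than this note shows. Statements on the series, on what has been measured and on what is new or still open speak of the compounds shown alone.

Compound 1 `CC(C)C1NC(=O)N(C2CCCCC2)C1=O` and compound 2 `O=C1NC(c2ccccc2)C(=O)N1Cc1ccccc1` share a five-membered core with two nitrogens and were both tested in a functional assay on HeLa cells (Homo sapiens) for inhibition; on this read-out higher numbers stand for weaker inhibition and lower numbers for stronger inhibition. In this assay compound 1 gave only a limit, > 100000 nM. Compound 2 likewise gave only a limit, > 100000 nM. Compound 2 therefore stands at the limit of > 100000 nM in this assay, at which 2 of the 2 values shown sit, so nothing separates it from compound 1 on the numbers shown. Compound 3 `CCC(C)C1NC(=O)N(Cc2ccccc2)C1=O` has not yet been measured. It differs from compound 2 in one place (sec-butyl in place of phenyl on a saturated ring carbon). Among the measured compounds shown here, no step between two measured compounds is known here, so the effect of this change can only be expected. Because both known compounds sit at the limit of > 100000 nM in this assay, at which 2 of the 2 values shown sit, no change beyond the scatter is expected in this assay, and compound 3 is estimated at 150000 nM, within a range from 50000 nM to 500000 nM. The expected step is a step that the limit leaves unreadable from compound 2 to compound 3, no more than the scatter allows.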

Compound 3, half-maximal inhibitory concentration: > 100000 nM
Compound 3 gave a limit, no number; the forecaster's own chance of this, stated with the estimate: 85%; the middle value does not contradict the limit.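

Compound 2 and compound 3 both gave only a limit, so the swap of phenyl for sec-butyl cannot be read as a step, as all the results sit at one limit: the limit of > 100000 nM in this assay, at which 3 of the 3 values shown sit. The compounds shown leave open which change to the shared core, if any, would give a measurable value in this assay.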